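A few compounds are considered here, and "the series" means these few. Any claim that something is new, unique, unknown or untested is made for them only; others in the source may bear on it.

Working notes on the series. In a functional assay on A549 cells (Homo sapiens) for inhibition, read by MTT assay, with a stated time of 72 h (a higher number here means a weaker inhibitor, a lower number a stronger inhibitor), compound 1 (`O=C1C=CC(O)(c2cc3ccccc3n2S(=O)(=O)c2ccccc2)C=C1`) gives 500 nM and compound 2 (`Cc1ccc(S(=O)(=O)n2c(C3(O)C=CC(=O)C=C3)cc3ccccc32)cc1`) gives 500 nM, so compound 2 stands level with compound 1 at the digits reported. Among the measured compounds shown here, the only measured step, methyl in place of hydrogen on an aromatic carbon, reads no change at the digits printed from compound 1 to compound 2 (within the scatter). Compound 3 (`O=C1C=CC(O)(c2cc3ccccc3n2S(=O)(=O)c2cccnc2)C=C1`) has not been measured. Its change from compound 2 is pyridin-3-yl in place of 4-methylphenyl on a sulfonyl sulfur. For the measured compounds named here, no measured compound carries pyridin-3-yl, so the single measured step is weak guidance for this larger change. Going by the values given here, with only that flat step to go on, no shift beyond the scatter is expected in this assay, and no direction is favoured. The estimated step is no change at the digits printed from compound 2 to compound 3 (within the scatter). For compound 3 the expected value is 500 nM, with an estimated range of 200 nM to 1200 nM.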

Compound 3, half-maximal inhibitory concentration: 500 nM
Beside the measured number, compound 3's estimate shows no gap at the digits printed; measured number inside the range.
By their numbers in this assay, from the lowest: compounds 1, 2 and 3 (each within the scatter of the next).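

The step of no change at the digits printed from compound 2 to compound 3 (within the scatter) in this assay replaces 4-methylphenyl with pyridin-3-yl on the sulfonyl sulfur, and the comparison with the unsubstituted ring reads no change at the digits printed from compound 1 to compound 3 (within the scatter) on the same swap. The earlier pair varied only a methyl on a ring of carbon only, whereas this change brings in a ring with 1 hetero atom and 1 hydrogen-bond acceptor, and the read-out still does not separate the three aryl groups. No measurement on hand accounts for this flat reading.

The compounds shown leave open whether any group on the sulfonyl sulfur moves the value, since all three carry a six-membered aromatic ring there. A saturated amine such as piperidin-1-yl, a benzoic acid ring or a longer alkyl chain at this place would test that limit.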